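The compounds below may be only part of what the source reports. "The series", "measured", "known", "first", "only" and "open" are said of these compounds alone.

Of the compounds shown here, two of a shared core have been measured so far. Compound 1, `CCNC(=O)[C@H]1CC[C@@H](n2/c(=N/C(=O)c3ccccc3)[nH]c3ccc(CN4CCCCC4)cc32)CC1`, was tested in an in vitro ADME assay on microsomes from liver (Homo sapiens) for metabolic stability (a higher number here means faster removal of the compound, a lower number slower removal), and gives 194 mL.min-1.g-1. Compound 2, `CC(C)NC(=O)[C@H]1CC[C@@H](n2/c(=N/C(=O)c3cccnc3)[nH]c3ccc(CN4CCC(C(C)(C)O)CC4)cc32)CC1`, was tested in this assay and gives 47 mL.min-1.g-1. Of these two numbers, the one for compound 2 is the lower, and the gap between them is larger than the usual scatter of repeated runs, so compound 2 is the slower-cleared of the pair on the numbers shown. For the measured compounds named here, no step between two measured compounds that differ in only one place is available here.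

Compound 3, `CC(C)NC(=O)[C@H]1CC[C@@H](n2/c(=N/C(=O)c3cc(F)cc(Cl)c3)[nH]c3ccc(CN4CCC(C(C)(C)O)CC4)cc32)CC1`, has not yet been measured in this assay. It differs from compound 2 in one place: 3-chloro-5-fluorophenyl in place of pyridin-3-yl on a carbonyl carbon. Going by the values given here, with only two measured compounds, neither a close neighbour of this change, there is no measured step to lean on. The expectation is nevertheless that the number for compound 3 will rise from that of compound 2, by a step of a 2.0-fold higher number from compound 2 to compound 3 (0.31 log units; beyond the scatter). Compound 3 is therefore estimated at 95 mL.min-1.g-1, within a range from 45 mL.min-1.g-1 to 200 mL.min-1.g-1.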

Compound 3, intrinsic clearance in microsomes: 83 mL.min-1.g-1
Compound 3: the middle estimate sits 1.1-fold (0.06 log units) above what was measured; the measured number falls inside the stated range.
By their numbers in this assay, from the lowest: compounds 2 and 3 (each within the scatter of the next); then compound 1.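

For the compounds shown here, compound 1 and compound 2 differ in more than one place, so they could not show what any single position contributes; this result is the first reading of one place alone, the carbonyl carbon whose other neighbour is an amide-type nitrogen. In this assay, exchanging pyridin-3-yl for 3-chloro-5-fluorophenyl there gives a 1.8-fold higher number from compound 2 to compound 3 (0.25 log units; within the scatter), so compound 2 and compound 3 cannot be told apart by this measurement. At this position, then, a six-membered aromatic ring of carbon only, carrying chlorine and fluorine, can take the place of a ring holding a nitrogen without a step that stands clear of the scatter of repeated runs, at least with the rest of the molecule as it is in these two compounds.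

Still open, on these data alone, is how 3-chlorophenyl or 3-fluorophenyl alone, or a phenyl ring carrying a nitrile or a carboxylic acid, would read in this assay on this same carbonyl carbon, and whether the two halogens of compound 3 count separately or only together. Nothing on hand bears on what lies behind the size of this step.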